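A few compounds are considered here, and "the series" means these few. Any claim that something is new, unique, unknown or untested is made for them only; others in the source may bear on it.

Compound 3 `COc1ccc(NC(=S)Nc2nc[nH]n2)cc1` is one of three close analogues measured in an ADME assay on MT4 cells (Homo sapiens) for cytotoxicity, read by MTT assay, with a stated time of 96 h; a lower number here means that less compound is tolerated, a higher number that more compound is tolerated. Compound 3 reaches only the limit of this assay, > 100000 nM. Compound 2 `O=C(NC(=S)Nc1nc[nH]n1)c1ccccc1` also reaches only that limit, > 100000 nM. Compound 1 `Cc1ccc(NC(=S)Nc2nc[nH]n2)cc1` gives 59000 nM. For the measured compounds named here, the one measured step that bears on the change to compound 4 `S=C(Nc1ccccc1)Nc1nc[nH]n1`, in which (hydrogen in place of methoxy on an aromatic carbon), is an at least 1.6-fold higher number from compound 1 to compound 3 (0.22 log units; that floor lies within the scatter), and because the limit of > 100000 nM in this assay, at which 2 of the 3 values shown sit, caps two of the three values, that step is known only as a floor. Compound 4 is therefore expected to show an at least 1.2-fold lower number from compound 3 to compound 4 (0.09 log units; that floor lies within the scatter), with no direction beyond the scatter that the numbers would support. The estimate for compound 4 is 80000 nM, with a range from 40000 nM to 200000 nM.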

Compound 4, half-maximal cytotoxic concentration: > 100000 nM
Compound 4 gave a limit, no number (the forecaster's own chance of this, stated with the estimate: 45%); middle value at least 1.2-fold (0.09 log units) from the limit.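

In this assay compound 4 gives a limit and not a number, so the unsubstituted ring joins the methoxy compound at the cap, and the steps that the two limits bound cannot be read. Hydrogen in place of methyl gives an at least 1.6-fold higher number from compound 1 to compound 4 (0.22 log units; that floor lies within the scatter), a second floor of the same size as the one for methoxy. Compound 1 stays the only one of these ring-substituted analogues with a number, and its steps remain floors because of the cap: the limit of > 100000 nM in this assay, at which 3 of the 4 values shown sit.

On these data alone, whether methyl truly differs from hydrogen or methoxy stays open. Also open, as far as these compounds go, is how an amine or a carboxylic acid on this aromatic carbon would read in this assay.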